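Swapping a fluorophenyl for a pyridyl on a shared core

A few compounds are considered here, and "the series" means these few. Any claim that something is new, unique, unknown or untested is made for them only; others in the source may bear on it.

Measured compounds:
- compound 1, `Cc1ccc2c(c1)c([C@H](C)Nc1ncnc3[nH]cnc13)nn2-c1cccnc1`, -10%
- compound 2, `C[C@H](Nc1ncnc2[nH]cnc12)c1nn(-c2cccc(F)c2)c2cc(F)ccc12`, -17%
- compound 3, `C[C@H](Nc1nc(N)nc(N)c1C#N)c1nn(-c2cccnc2)c2cc(C(F)(F)F)ccc12`, 60%

In a functional assay on Bel-7402 cells (Homo sapiens) for inhibition, read by sulforhodamine B assay, with a stated time of 72 h, tested at 10 uM (a lower number here means less inhibition, a higher number more inhibition at the concentration tested (going by the name of the read-out)), compound 2 gives -17%, the lowest of the three numbers, meaning essentially no inhibition of cell growth. Compound 1, which shares the same core but carries a different group on the aromatic nitrogen, gives -10%, a reading within the usual scatter of compound 2, so the two cannot be told apart. Compound 3, built on a different core, gives 60%, well beyond the scatter from compound 2.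

Compound 4, `C[C@H](Nc1ncnc2[nH]cnc12)c1nn(-c2ccncc2)c2cc(F)ccc12`, differs from compound 2 in one place: pyridin-4-yl in place of 3-fluorophenyl on an aromatic nitrogen. Among the compounds with values here, no measured pair shows this exact change. The closest guide is compound 1, where a pyridinyl group on that same aromatic nitrogen still gave only -10%. A step of no size beyond the scatter is therefore expected in this assay, a number 9 percentage points higher from compound 2 to compound 4 (within the scatter). Compound 4 is estimated at -8%, with a range from -30% to 20%.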

Compound 4, a percentage reported as inhibition, at one concentration (the size of the read-out at that concentration, not a potency): 16%
The estimate for compound 4 lay 24 percentage points below the measured number; measured number inside the range.
By their numbers in this assay, from the lowest: compounds 2 and 1 (each within the scatter of the next); then compound 4; then compound 3.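

In this assay, the group on this aromatic nitrogen clearly matters: pyridin-4-yl in place of 3-fluorophenyl gives a number 33 percentage points higher from compound 2 to compound 4 (beyond the scatter), so exchanging one six-membered aromatic ring for another is enough to move the reading. The earlier compounds shown here could not show this, as no two of them differed in only one place. No measurement shown here accounts for the step.

This single pair leaves open whether the gain comes from adding the ring nitrogen or from losing the fluorine, and a plain phenyl ring at this position would help separate the two. As far as these compounds go, it also remains open whether the same swap would have a similar effect on the core of compound 3, which carries a different group where compound 2 and compound 4 share theirs.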